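A few compounds are considered here, and "the series" means these few. Any claim that something is new, unique, unknown or untested is made for them only; others in the source may bear on it.

Measured in a functional assay on K562 cells (Homo sapiens) for antiproliferative activity, read by MTT assay, with a stated time of 72 h; on this read-out lower numbers stand for stronger inhibition and higher numbers for weaker inhibition:
- compound 1 `COc1cc(C(=O)c2sc3ccccc3c2-c2ccc(SC)cc2)cc(OC)c1OC`: 1800 nM
- compound 2 `COc1ccccc1-c1c(C(=O)c2cc(OC)c(OC)c(OC)c2)sc2ccccc12`: 3400 nM
- compound 3 `COc1ccc(-c2c(C(=O)c3cc(OC)c(OC)c(OC)c3)sc3ccccc23)c(OC)c1`: 4100 nM

Compound 3 lies at the high end of these numbers. The data show a 1.2-fold higher number from compound 2 to compound 3 (0.08 log units; within the scatter), and also a 2.3-fold higher number from compound 1 to compound 3 (0.36 log units; beyond the scatter). Compound 4 `CCOc1ccc(-c2c(C(=O)c3cc(OC)c(OC)c(OC)c3)sc3ccccc23)cc1` follows from compound 3 by one exchange: 4-ethoxyphenyl in place of 2,4-dimethoxyphenyl on an aromatic carbon, with 4-ethoxyphenyl in place of 2,4-dimethoxyphenyl on an aromatic carbon. Going by the values given here, no measured step makes this exact exchange. The closest guide is compound 1, whose 4-(methylsulfanyl)phenyl, like 4-ethoxyphenyl, carries one group, and which gives 1800 nM. A modest move toward that number is therefore expected, the reverse of a 2.3-fold higher number from compound 1 to compound 3 (0.36 log units; beyond the scatter). The expected change is a 2.1-fold lower number from compound 3 to compound 4 (0.31 log units; beyond the scatter). For compound 4 the estimated value in this assay is 2000 nM, with an expected range of 700 nM to 4500 nM.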

Compound 4, half-maximal inhibitory concentration: 3100 nM
Compound 4: the middle estimate sits 1.6-fold (0.19 log units) below what was measured, and the stated range covers the measured number.
By their numbers in this assay, from the lowest: compounds 1, 4, 2 and 3 (each within the scatter of the next, the first and the last beyond it).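

Placing 4-ethoxyphenyl at this carbon gives a 1.3-fold lower number from compound 3 to compound 4 (0.12 log units; within the scatter) and a 1.1-fold lower number from compound 2 to compound 4 (0.04 log units; within the scatter) on the one side, and ethoxy in place of methylsulfanyl gives a 1.7-fold higher number from compound 1 to compound 4 (0.24 log units; within the scatter) on the other. Compound 4 thus lies within the scatter of all three earlier compounds, although compound 1 and compound 3 lie beyond the scatter of each other. No evidence is available that bears on this result. Going by these compounds, what remains open is how an amine or a carboxylic acid on this phenyl ring, or an alkoxy chain longer than ethoxy, would compare.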